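The source may report more compounds than this note shows. Statements on the series, on what has been measured and on what is new or still open speak of the compounds shown alone.

Working notes on the series.

The parent is compound 1, `CC(C)=CCC[C@H](C)c1ccc(C)cc1O`. In a functional assay on MCF7 cells (Homo sapiens) for inhibition, read by MTT assay, with a stated time of 72 h (a lower number here means a stronger inhibitor, a higher number a weaker inhibitor), compound 1 sits at the assay limit, > 20000 nM, which is a bound and not a number. Compound 2, `CC(C)=CCC[C@H](C)c1ccc(C)c(CNCCO)c1O`, carries a ((2-hydroxyethyl)amino)methyl on an aromatic carbon of the shared core. In this assay compound 2 likewise returns only the limit, > 20000 nM. The step that the two limits leave unreadable from compound 1 to compound 2 therefore cannot be read, since both ends sit at the limit of > 20000 nM in this assay, at which 2 of the 3 values shown sit. Among the measured compounds shown here, compound 3, `CC(C)=CCC[C@H](C)c1ccc(C)c2c1OCN(CC1CCNCC1)C2`, closes a ring onto the core and is the one member with a number: in this assay compound 3 gives 8100 nM.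

Compound 4, `CC(C)=CCC[C@H](C)c1ccc(C)c(CNCCCCC(=O)O)c1O`, differs from compound 2 by 2-carboxyethyl in place of hydroxy on a saturated chain carbon, two bonds along the chain from an amine nitrogen. For the measured compounds named here, no measured step shares this change: the only single-place step, from compound 1 to compound 2, is unreadable, and compound 3 differs from compound 2 in a different way. Where compound 2 stands is known only as a limit, so any step can be stated only from that bound. Compound 4 is expected to remain weak, with the step that the limit leaves unreadable from compound 2 to compound 4 expected to stay within the scatter. For compound 4 the estimate is 25000 nM, spanning 8000 nM to 80000 nM, with a substantial chance that only a limit is reported.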

Compound 4, half-maximal inhibitory concentration: > 20000 nM
Compound 4 ended at the assay's limit; the forecaster's own chance of this, stated with the estimate: 70%; the middle value lies beyond the limit too.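

No new step can be read between compound 2 and compound 4, as both return only a limit and not a number in this assay, and the replacement of hydroxy by 2-carboxyethyl has no readable size: the limit of > 20000 nM in this assay, at which 3 of the 4 values shown sit.

Going by these compounds, whether any change to this chain on the amine nitrogen can bring a value inside the limit in this assay stays open.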